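The source may report more compounds than this note shows. Statements on the series, on what has been measured and on what is new or still open speak of the compounds shown alone.

Compound 1 `CN1CCN(CC(=O)NC2(c3ccc(Cl)cc3)C(=O)Nc3cc(Cl)c(Cl)cc32)CC1` is the starting point of this account. In an in vitro functional assay on CHO-CREluc cells for antagonist activity at growth hormone secretagogue receptor type 1 (Homo sapiens), read by a luciferase reporter, with a stated time of 4 h (on this read-out higher numbers stand for weaker inhibition and lower numbers for stronger inhibition), compound 1 gives only a limit, > 10000 nM, and so no number is known for it. Compound 2 `CN1CCN(CC(=O)NC2(c3ccc(C(C)(C)C)cc3)C(=O)Nc3cc(Cl)c(Cl)cc32)CC1` carries tert-butyl in place of chloro on an aromatic carbon, and in this assay compound 2 gives 1470 nM, a step of an at least 6.8-fold lower number from compound 1 to compound 2 (0.83 log units; beyond the scatter). Compound 3 `Cc1cc2c(cc1Cl)C(NC(=O)CN1CCN(C)CC1)(c1ccc(Cl)cc1)C(=O)N2` carries methyl in place of chloro on an aromatic carbon, and in this assay compound 3 gives 251 nM, a step of an at least 39-fold lower number from compound 1 to compound 3 (1.60 log units; beyond the scatter). Both steps are bounded on one side by the fact that compound 1 sits at the limit of > 10000 nM in this assay, at which 1 of the 3 values shown sits.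

Compound 4 `CCN1CCN(CC(=O)NC2(c3ccc(Cl)cc3)C(=O)Nc3cc(Cl)c(Cl)cc32)CC1` differs from compound 1 in another place altogether: methyl in place of hydrogen on a saturated chain carbon bound to an amine nitrogen in a ring, that is, methyl to ethyl on the 4-methylpiperazin-1-yl group, giving 4-ethylpiperazin-1-yl. Neither measured step touches this part of the shared core, so neither gives direct guidance; both concern an aromatic carbon and tell nothing about the amine nitrogen in a ring. The expectation for the step from compound 1 to compound 4 is therefore no change beyond the scatter, a number no higher from compound 1 to compound 4 (the limit leaves the size open). Compound 4 is accordingly estimated at 10000 nM in this assay, within a range from 3000 nM to 30000 nM, with a fair chance that only a limit is reported again.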

Compound 4, half-maximal inhibitory concentration: 110 nM
For compound 4 the middle estimate is 91-fold (1.96 log units) above the measured one; the measured number lies below the stated range.
By their numbers in this assay, from the lowest: compound 4; then compound 3; then compound 2. At a limit, above all of these: compound 1.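

In this assay the change from 4-methylpiperazin-1-yl to 4-ethylpiperazin-1-yl gives an at least 90-fold lower number from compound 1 to compound 4 (1.95 log units; beyond the scatter), so the amine end of compound 1 responds strongly to a change in its substituent. The earlier steps shown here concerned only an aromatic carbon, and they said nothing about this part of the molecule; the new step shows that activity can also be gained here, with the chloro groups of compound 1 left in place. The entering group is a single methyl, with 1 heavy atom, no ring and no hydrogen-bond donors or acceptors, and the true size of the step remains bounded on one side: the limit of > 10000 nM in this assay, at which 1 of the 4 values shown sits.

With only methyl and ethyl shown at this position, it remains open whether a propyl group, a longer chain or a cyclopropyl ring on the piperazine nitrogen would extend the gain or lose it, and whether hydrogen there would differ from methyl. From the compounds shown here alone, it also remains open whether the ethyl change would add to the aromatic changes of compound 2 and compound 3 if the two were combined in one molecule.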